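The source may report more compounds than this note shows. Statements on the series, on what has been measured and on what is new or still open speak of the compounds shown alone.

Measured in a functional assay on HepG2 cells (Homo sapiens), read by MTT assay, with a stated time of 48 h; a higher number here means a weaker inhibitor, a lower number a stronger inhibitor:
- Compound 1 `CCN(CC)CCCNC(=O)c1ccc(C(CC)(CC)c2ccc(OCC(=O)C(C)(C)C)c(C)c2)n1CC`: 180 nM
- Compound 2 `CCOC(=O)CN(C)C(=O)c1ccc(C(CC)(CC)c2ccc(OCC(O)C(C)(C)C)c(C)c2)n1CC`: > 50000 nM, a limit of the assay and not a number
- Compound 3 `CCn1c(C(=O)NCCN(C)C)ccc1C(CC)(CC)c1ccc(OCC(O)C(C)(C)C)c(C)c1`: 870 nM

Of the two actual numbers, compound 3 has the higher, 870 nM, while compound 1 has the lower, 180 nM, and that gap lies beyond the scatter. Compound 4 `CCN(CC)CCCNC(=O)c1ccc(C(CC)(CC)c2ccc(OCC(O)C(C)(C)C)c(C)c2)n1CC` differs from compound 3 only in its amide chain: (diethylamino)methyl in place of dimethylamino on a saturated chain carbon, two bonds along the chain from an amide-type nitrogen. Cut one bond further out, (3-(diethylamino)propyl)amino stands in place of (2-(dimethylamino)ethyl)amino.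

Among the measured compounds shown here, one measured step bears on this part of the molecule. It is an at least 57-fold lower number from compound 2 to compound 3 (1.75 log units; beyond the scatter), with (2-(dimethylamino)ethyl)amino replacing ((ethoxycarbonyl)methyl)(methyl)amino on a carbonyl carbon. That large step starts from a limit. The new change is of another kind, since it swaps dimethylamino for (diethylamino)methyl instead of removing the ethoxycarbonyl group, so nothing of that size is expected. For the measured compounds named here, a modest move toward a lower number in this assay seems more likely, with compound 1 at 180 nM marking the low side of the numbers measured so far. The expected change is a 2.2-fold lower number from compound 3 to compound 4 (0.34 log units; beyond the scatter), which may prove hard to separate from the scatter. For compound 4 the estimated value is 400 nM, with an expected range of 130 nM to 1200 nM.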

Compound 4, half-maximal inhibitory concentration: 1100 nM
Beside the measured number, compound 4's estimate is 2.8-fold (0.44 log units) below it; the measured number falls inside the stated range.
By their numbers in this assay, from the lowest: compound 1; then compounds 3 and 4 (each within the scatter of the next). At a limit, above all of these: compound 2.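

In this assay, the larger amide chain brings no measurable change: with (diethylamino)methyl in place of dimethylamino, the result is a 1.3-fold higher number from compound 3 to compound 4 (0.10 log units; within the scatter), so this part of the chain tolerates the added carbons, at least in these two compounds. The large step away from the ester-bearing amide holds with this second amine chain too, at an at least 45-fold lower number from compound 2 to compound 4 (1.65 log units; beyond the scatter), though it starts from compound 2, whose value is a limit of the assay and not a number: the limit of > 50000 nM in this assay, at which 1 of the 4 values shown sits. With the amide chain held constant, the other end of the molecule matters more, as 1-hydroxy-2,2-dimethylpropyl in place of (tert-butyl)carbonyl gives a 6.1-fold higher number from compound 1 to compound 4 (0.79 log units; beyond the scatter).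

On these data alone, what a 2-(diethylamino)ethyl or a 3-(dimethylamino)propyl chain would give stays open, so the effects of chain length and of the amine end cannot be told apart here. Also open, as far as these compounds go, is how a piperidine or morpholine at the chain end, or a carboxylic acid in place of the ethyl ester of compound 2, would read in this assay.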